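A few compounds are considered here, and "the series" means these few. Any claim that something is new, unique, unknown or untested is made for them only; others in the source may bear on it.

Compound 1 `Cc1ccc(/N=C2/NC(=O)/C(=C/c3ccccn3)S2)cc1` and compound 2 `O=C1N/C(=N/c2cccc([N+](=O)[O-])c2)S/C1=C\c1ccccn1` are the measured members of this series. In a functional assay on the whole organism (strain Swiss albino) for inhibition, with Mus musculus as the target, in the writhing test, with stated times of 30 min and 15 min, at a dose of 50 mg/kg by the oral route (on this read-out lower numbers stand for less inhibition and higher numbers for more inhibition at the one dose given (going by the name of the read-out)), compound 1 gives 43.2%, the lower of the two numbers recorded; compound 2 gives 62.3%, a gap beyond the usual scatter. Among the measured compounds shown here, no pair of measured compounds differing in a single place is available, so the size of a one-place change is not known from these two. Compound 3 `O=C1N/C(=N/c2ccc(Br)cc2)S/C1=C\c1ccccn1` is not yet measured; it differs from compound 1 by bromo in place of methyl on an aromatic carbon. A modest rise is expected, a number 8.8 percentage points higher from compound 1 to compound 3 (within the scatter), though it may fall within the scatter. Compound 3 is estimated at 52%, with a range from 36% to 68%.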

Compound 3, a percentage reported as inhibition, in the whole organism at one dose (the size of the read-out at that dose, not a potency): 28.7%
The estimate for compound 3 lay 23.3 percentage points above the measured number; the measured number lies below the stated range.
By their numbers in this assay, from the lowest: compound 3; then compound 1; then compound 2.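

Among the compounds shown here, on the six-membered aromatic ring of carbon only, para to a large group, the change from 4-methylphenyl to 4-bromophenyl gives the first one-place step: in this assay it reads a number 14.5 percentage points lower from compound 1 to compound 3 (beyond the scatter), so the read-out responds to this position and bromo does not raise it over methyl. Nothing available accounts for this step.

The compounds shown leave open how an amine or a carboxylic acid at this place would read, and whether bromo on another ring carbon would move the number the same way.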